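Phenyl for methyl on the five-membered ring of compound 2

The compounds below may be only part of what the source reports. "The series", "measured", "known", "first", "only" and "open" are said of these compounds alone.

Compound 1 `CC(C)(C)NCC(O)COc1ncns1` and compound 2 `Cc1nsc(OCC(O)CNC(C)(C)C)n1` share one core and differ only by methyl in place of hydrogen on an aromatic carbon. In a functional assay on the whole organism (heart, strain mongrel) for inhibition, with Canis familiaris (Canis lupus familiaris) as the target, with a stated time of 20 min, at a dose of 14.58 mg/kg by the intravenous route (a lower number here means a weaker effect, a higher number a stronger effect of the compound at the dose given), compound 1 gives 97.5%, and in this assay compound 2 gives 92.3%. Among the compounds with values here, the one measured step, a number 5.2 percentage points lower from compound 1 to compound 2 (within the scatter), shows that a small group entering at this aromatic carbon leaves the read-out essentially where it was, and compound 2 stands within the scatter of compound 1 on the two numbers known so far.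

Compound 3 `CC(C)(C)NCC(O)COc1nc(-c2ccccc2)ns1` continues at the same place: phenyl in place of methyl on an aromatic carbon. Within the data shown here, no measured step covers a group as large as phenyl; the only step that bears on the position, a number 5.2 percentage points lower from compound 1 to compound 2 (within the scatter), was within the scatter. Given that both measured compounds already sit near the ceiling of this assay, the expectation is a step of a number 4.3 percentage points lower from compound 2 to compound 3 (within the scatter), that is, no change beyond the scatter, with some room for a drop. Compound 3 is therefore estimated at 88%, within a range from 70% to 99%.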

Compound 3, a percentage reported as inhibition, in the whole organism at one dose (the size of the read-out at that dose, not a potency): 68%
Compound 3: the middle estimate sits 20 percentage points above what was measured; measured number outside the range, below it.
By their numbers in this assay, from the lowest: compound 3; then compounds 2 and 1 (each within the scatter of the next).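

In this assay, within the data shown here, this aromatic carbon between two ring nitrogen atoms is not indifferent to what it carries: the change to phenyl gives a number 24.3 percentage points lower from compound 2 to compound 3 (beyond the scatter) and, set against the hydrogen, a number 29.5 percentage points lower from compound 1 to compound 3 (beyond the scatter), the only steps at this place that lie beyond the scatter. The tolerance seen so far therefore holds for hydrogen and methyl only and does not extend to phenyl, although compound 3 still retains a clear effect at this dose, 68%, so the change weakens the read-out without abolishing it. Nothing available on these compounds offers an explanation for the drop.

As far as these compounds go, with only hydrogen, methyl and phenyl at this carbon, it remains open whether the drop tracks the number of heavy atoms, which ethyl or isopropyl would test, or goes with the aromatic ring itself, which cyclohexyl would separate from phenyl. Also open, from the compounds shown here alone, is how a methoxy group or a chlorine atom on the phenyl ring would move the read-out, and whether a single-dose read-out of this kind would rank these compounds as a full dose range would.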